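Amide series: carboxypropyl in place of methyltetrazolyl

The compounds below may be only part of what the source reports. "The series", "measured", "known", "first", "only" and "open" are said of these compounds alone.

Of the compounds shown here, three have been measured so far. Compound 1 `O=C(Nc1nnn[nH]1)c1coc(=O)c2ccccc12` gives 0% in a functional assay on the whole organism for inhibition, with Rattus norvegicus as the target, with a stated time of 30 min, at a dose of 1 mg/kg by the intravenous route; on this read-out higher numbers stand for more inhibition at the one dose given (going by the name of the read-out) and lower numbers for less inhibition. Compound 2 `O=C(O)CCCCCNC(=O)c1cc(=O)c2ccccc2o1` gives 0% in this assay, and compound 3 `Cn1nnnc1NC(=O)c1cc(=O)c2ccccc2o1` gives 0%. On these numbers compound 3 stands level with compound 1 and with compound 2 at the digits shown; the gaps lie within the scatter, so no order among the three can be stated and none of them shows measurable inhibition at the dose used.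

Compound 4 `O=C(O)CCCNC(=O)c1cc(=O)c2ccccc2o1` has not yet been measured. The change from compound 3 to compound 4 is 3-carboxypropyl in place of 1-methyl-1H-tetrazol-5-yl on an amide-type nitrogen. Within the data shown here, no step between measured compounds is available, so the size of this change cannot be read from a measured pair. Among the measured compounds shown here, compound 2 gives 0%, and nothing among the measured numbers points to an increase from a chain bearing an acid on the amide-type nitrogen. The expected step is none beyond the scatter, that is no change at the digits printed from compound 3 to compound 4 (within the scatter). Compound 4 is therefore expected to give 0%, with a range from 0% to 10%.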

Compound 4, a percentage reported as inhibition, in the whole organism at one dose (the size of the read-out at that dose, not a potency): 0%
For compound 4 middle estimate and measured number coincide at the digits printed; the measured number falls inside the stated range.
By their numbers in this assay, from the lowest: compounds 1, 2, 3 and 4 (each within the scatter of the next).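

In this assay, 3-carboxypropyl in place of 1-methyl-1H-tetrazol-5-yl on the amide-type nitrogen gives no change at the digits printed from compound 3 to compound 4 (within the scatter) on the shared core, so this position now has a measured pair, and the ring and the open chain read alike. Carboxy in place of 2-carboxyethyl on a saturated chain carbon, three bonds along the chain from an amide-type nitrogen, gives no change at the digits printed from compound 2 to compound 4 (within the scatter), so the length of the acid-bearing chain does not register in this pair either. Nothing available explains these flat readings.

As far as these compounds go, since all these compounds share one reading with no measurable inhibition, it stays open whether either change would matter on a compound that shows some. Also open, from the compounds shown here alone, is whether an amine or a methyl ester in place of the terminal carboxylic acid would read differently in this assay on this core.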